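The compounds below may be only part of what the source reports. "The series", "measured", "known", "first", "only" and "open" are said of these compounds alone.

In a toxicity assay on THP-1 cells (Homo sapiens) for inhibition (on this read-out higher numbers stand for lower toxicity in this test and lower numbers for higher toxicity in this test), compound 1 `COc1ccc(-c2cnc(NC(=O)c3ccc(F)cc3)n2C)cc1` gives only a limit of >= 50000 nM on the shared core. Compound 2 `COc1ccc(-c2cnc(NC(=O)c3cccc(F)c3)n2C)cc1` also gives only a limit of > 100000 nM in this series. Compound 3 `COc1ccc(-c2cnc(NC(=O)c3cccc(OC)c3)n2C)cc1` likewise stands at a limit of > 100000 nM and has no exact number. Among the compounds with values here, compound 4 `COc1ccc(-c2cnc(NC(=O)C3CCCC3)n2C)cc1` is unmeasured and carries cyclopentyl in place of 3-methoxyphenyl on a carbonyl carbon as its only change. The measured steps at this group are a step that the two limits leave unreadable from compound 1 to compound 2 and a step that the two limits leave unreadable from compound 1 to compound 3 and a step that the two limits leave unreadable from compound 2 to compound 3 so none offers a size. Within the data shown here, no compound with a non-aromatic ring at this place has been measured. Among the measured compounds shown here, the expected change is a number no higher from compound 3 to compound 4 (the limit leaves the size open) with no direction readable in this assay so far. Compound 4 is expected at 100000 nM with an estimated range of 30000 nM to 200000 nM for now.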

Compound 4, half-maximal cytotoxic concentration: > 100000 nM
Compound 4 ended at the assay's limit (the forecaster's own chance of this, stated with the estimate: 75%); the middle value sits exactly at the limit.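

Compound 4 gives > 100000 nM in this assay, which is a limit. With limits on both sides, its steps from compound 1, compound 2 and compound 3 cannot be read. The compounds shown leave open whether the group on the carbonyl carbon changes this read-out at all.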